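This account rests on a few compounds, and the source may have more. Where it says the series, first, only, none or still open, it means among the compounds named here.

Compound 1 `CC(C)C[C@H](NC(=O)c1cc(Cl)ccc1OCCNC(=O)OC(C)(C)C)C(=O)Nc1ccc([N+](=O)[O-])cc1Cl` and compound 2 `CC(C)C[C@H](NC(=O)c1cc(Cl)ccc1OCCN)C(=O)Nc1ccc([N+](=O)[O-])cc1Cl` share one core, while compound 3 `CC(C)[C@H](NC(=O)c1cc(Cl)ccc1OCCNC(=O)OC(C)(C)C)C(=O)Nc1cc(F)cc(C(F)(F)F)c1` and compound 4 `CC(C)[C@H](NC(=O)c1cc(Cl)ccc1OCCN)C(=O)Nc1cc(F)cc(C(F)(F)F)c1` share another; the difference between the two cores is not broken down here. In a functional assay on MCF7 cells (Homo sapiens) for inhibition, read by MTT assay, with a stated time of 72 h (on this read-out lower numbers stand for stronger inhibition and higher numbers for weaker inhibition), compound 1 gives > 10000 nM, which is a limit of the assay and not a number. Compound 2 likewise stops at the limit, > 10000 nM. The change hydrogen in place of tert-butoxycarbonyl on an amine nitrogen therefore gives a step that the two limits leave unreadable from compound 1 to compound 2 because both values sit at the limit of > 10000 nM in this assay, at which 2 of the 3 values shown sit. Among the measured compounds shown here, compound 3, the only one with a real number, gives 11500 nM. The same change, (hydrogen in place of tert-butoxycarbonyl on an amine nitrogen), is now made on compound 3. Because compound 3 gives 11500 nM close to the limit of > 10000 nM in this assay, at which 2 of the 3 values shown sit, the step to compound 4 is expected to be small, a 1.0-fold higher number from compound 3 to compound 4 (0.02 log units; within the scatter). Compound 4 is thus expected to give 12000 nM, most likely between 5000 nM and 30000 nM.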

Compound 4, half-maximal inhibitory concentration: > 10000 nM
Compound 4: a limit, no number; the forecaster's own chance of this, stated with the estimate: 60%; the middle value does not contradict the limit.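

Compound 4 gives > 10000 nM, a limit and not a number, so no step can be read from compound 3 to compound 4. On these data alone, whether hydrogen in place of tert-butoxycarbonyl changes the result in this assay at all stays open, on the core of compound 1 and on that of compound 3.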